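Swapping a benzyl for tert-butyl on the amide nitrogen

The source may report more compounds than this note shows. Statements on the series, on what has been measured and on what is new or still open speak of the compounds shown alone.

Compound 1 `C=CC1=C(C(=O)NCc2ccc(C)cc2)C(c2ccc(F)cc2)OC1`: > 100000 nM
Compound 2 `C=CC1=C(C(=O)NCC(C)C)C(c2ccc(Cl)c(Cl)c2)OC1`: 60100 nM
Compound 3 `C=CC1=C(C(=O)Nc2ccccc2)C(c2ccc(Cl)c(Cl)c2)OC1`: > 100000 nM

Of the compounds shown here, three sharing one core have been tested in a functional assay on HeLa cells (Homo sapiens) for cytotoxicity, read by MTT assay, with a stated time of 24 h; a higher number here means a weaker inhibitor, a lower number a stronger inhibitor. Compound 1 gives > 100000 nM, which is a limit of the assay rather than a number. Compound 3 likewise reaches only a limit, > 100000 nM. Compound 2 alone gives a number, 60100 nM. Among the measured compounds shown here, the single measured change, an at least 1.6-fold higher number from compound 2 to compound 3 (0.22 log units; that floor lies within the scatter), moves from a number to a limit, and at that floor it stays within the scatter. Because compound 1 sits at the limit of > 100000 nM in this assay, at which 2 of the 3 values shown sit, its place within this set cannot be fixed.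

Compound 4 `C=CC1=C(C(=O)NC(C)(C)C)C(c2ccc(F)cc2)OC1` is not yet measured; it differs from compound 1 by tert-butyl in place of 4-methylbenzyl on an amide-type nitrogen. Like compound 2, it carries a group with no ring on the amide nitrogen, whereas compound 1 and compound 3 carry groups holding a six-membered aromatic ring. Only compound 2 gave a number, so the expected step is an at least 1.1-fold lower number from compound 1 to compound 4 (0.04 log units; that floor lies within the scatter), a modest move toward a readable value. Compound 4 is therefore estimated at 90000 nM, ranging from 40000 nM to 250000 nM, with a limit still the likelier outcome.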

Compound 4, half-maximal inhibitory concentration: > 100000 nM
Compound 4 was reported as a limit; the forecaster's own chance of this, stated with the estimate: 60%; middle value at least 1.1-fold (0.04 log units) away from the limit.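

In this assay compound 4 gives > 100000 nM, which is a limit and not a number. Compound 1 and compound 4 thus stand at the same limit, and no step between them can be read: the limit of > 100000 nM in this assay, at which 3 of the 4 values shown sit.

As far as these compounds go, whether tert-butyl in place of 4-methylbenzyl on the amide-type nitrogen changes the activity at all stays open.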